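A Ring Swap on the Sulfonyl Sulfur of Compound 1

A few compounds are considered here, and "the series" means these few. Any claim that something is new, unique, unknown or untested is made for them only; others in the source may bear on it.

Compound 1 `O=S(=O)(Nc1ccc(-c2nc3ccccc3o2)cc1)c1cccs1` is the only one of the three measured compounds that returns a number in an assay on cells for inhibition of HSP60/HSP10 (Homo sapiens), with a stated time of 60 min; a higher number here means a weaker inhibitor, a lower number a stronger inhibitor: compound 1 gives 63000 nM. Compound 2 `O=S(=O)(Nc1ccc2oc(-c3ccccc3)nc2c1)c1ccc(Cl)c(Cl)c1` gives > 100000 nM in this assay, which is a limit of the assay and not a number. Compound 3 `O=S(=O)(Nc1ccc2oc(-c3ccccc3)nc2c1)c1cccc(C(F)(F)F)c1` likewise gives > 100000 nM in this assay, again a limit of the assay rather than a number. Compound 1 therefore stands alone as the sole numerical result, while the other two values correspond to the limit of > 100000 nM in this assay, at which 2 of the 3 values shown sit. No pair among these three compounds differs in a single place, so no measured step is available to guide the next change.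

Compound 4 `Cc1ccccc1S(=O)(=O)Nc1ccc(-c2nc3ccccc3o2)cc1` is not yet measured. It differs from compound 1 by 2-methylphenyl in place of thiophen-2-yl on a sulfonyl sulfur. For the measured compounds named here, with only one number in hand and no measured step to lean on, the change is expected to move the value little: the expected step of a 1.1-fold higher number from compound 1 to compound 4 (0.05 log units; within the scatter) lies within the scatter of repeated measurements. Compound 4 is accordingly estimated at 70000 nM in this assay, with a range from 25000 nM to 200000 nM.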

Compound 4, half-maximal inhibitory concentration: 85000 nM
Beside the measured number, compound 4's estimate is 1.2-fold (0.08 log units) below it; the measured number falls inside the stated range.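

In this assay, putting 2-methylphenyl in place of thiophen-2-yl on the sulfonyl sulfur gives a 1.3-fold higher number from compound 1 to compound 4 (0.13 log units; within the scatter). For the compounds shown here, this is the first measured step at this position, and it shows that a six-membered aromatic ring of carbon only can stand here in place of a five-membered aromatic ring with a hetero atom, with no change that can be told from the scatter. Neither compound 1 nor compound 4 moves away from the weak end of the read-out, where little room is left: the limit of > 100000 nM in this assay, at which 2 of the 4 values shown sit.

From the compounds shown here alone, whether an amine or a carboxylic acid on the ring at the sulfonyl sulfur would give a number clearly lower than those of compound 1 and compound 4 remains open. This single step also says nothing about changes elsewhere on the core of compound 1.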